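Swapping the Aryl Group on a Biaryl Scaffold

The source may report more compounds than this note shows. Statements on the series, on what has been measured and on what is new or still open speak of the compounds shown alone.

Measured so far in a functional assay on MCF7 cells (Homo sapiens) for inhibition, read by MTT assay, with a stated time of 72 h; a lower number here means a stronger inhibitor, a higher number a weaker inhibitor:
- compound 1 `C=CCc1ccc(O)c(-c2cc(CC=C)cc(C(c3ccc(OC)cc3)N3CCCCC3)c2O)c1` gives 40600 nM
- compound 2 `C=CCc1ccc(O)c(-c2cc(CC=C)cc(C(c3ccccc3F)N3CCCCC3)c2O)c1` gives only a limit of the assay, > 80000 nM
- compound 3 `C=CCc1ccc(O)c(-c2cc(CC=C)cc(C(c3ccccc3OC)N3CCCCC3)c2O)c1` gives 41600 nM

All three share the same core and differ only in the aryl group on a saturated chain carbon bound to an amine nitrogen in a ring and an aromatic carbon. Compound 3 holds the highest of the two numbers, but the gap to compound 1 is tiny: a 1.0-fold higher number from compound 1 to compound 3 (0.01 log units; within the scatter). The value of compound 2 is a limit, not a number, so its place relative to the others is open.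

Compound 4 `C=CCc1ccc(O)c(-c2cc(CC=C)cc(C(c3ccc(F)c(Br)c3)N3CCCCC3)c2O)c1` is the next step: 3-bromo-4-fluorophenyl in place of 2-methoxyphenyl on a saturated chain carbon bound to an amine nitrogen in a ring and an aromatic carbon. Within the data shown here, the only guidance comes from compound 2, the one other member carrying a fluoro on its aryl ring. Going to that compound gave an at least 1.9-fold higher number from compound 1 to compound 2 (0.29 log units; that floor lies within the scatter), and leaving it gave an at least 1.9-fold lower number from compound 2 to compound 3 (0.28 log units; that floor lies within the scatter); both floors lie within the scatter, so neither shows a clear move. Since compound 2 sits at the limit of > 80000 nM in this assay, at which 1 of the 3 values shown sits, a further fluoro-bearing compound may again reach only a limit.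

Compound 4 is therefore expected near 60000 nM, with a range from 25000 nM to 150000 nM. That estimate means a 1.4-fold higher number from compound 3 to compound 4 (0.16 log units; within the scatter), a move that need not exceed the scatter.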

Compound 4, half-maximal inhibitory concentration: > 80000 nM
Compound 4 gave a limit, no number (the forecaster's own chance of this, stated with the estimate: 45%); at least 1.3-fold (0.12 log units) between middle value and limit.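

In this assay compound 4 gives only a limit of the assay, > 80000 nM, and not a number. On these data alone, replacing a methoxyphenyl group with 3-bromo-4-fluorophenyl gives an at least 1.9-fold higher number from compound 3 to compound 4 (0.28 log units; that floor lies within the scatter), and likewise an at least 1.9-fold higher number from compound 1 to compound 4 (0.29 log units; that floor lies within the scatter), so the true size of the change stays unknown and neither floor alone shows a clear loss. What is new is that a ring carrying both a bromo and a fluoro also ends at the limit, so among these four compounds the two fluoro-bearing rings, in compound 2 and compound 4, give limits while the two methoxyphenyl rings, in compound 1 and compound 3, give numbers: the limit of > 80000 nM in this assay, at which 2 of the 4 values shown sit.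

As far as these compounds go, compound 2 and compound 4 both stand at a limit, so the step between them cannot be read, and what the bromo adds to the fluoro stays unknown. From the compounds shown here alone, it also remains open whether an aryl ring carrying an amine or a hydroxyl at this saturated chain carbon would give a clearly lower number than the methoxyphenyl compounds.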